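Swapping the nitrile of compound 1 for an alkyne

This account rests on a few compounds, and the source may have more. Where it says the series, first, only, none or still open, it means among the compounds named here.

Compound 1 `CC(C)(C)C1CSC(c2ccc(C#N)cc2)SC1` gives 4.38 in a physicochemical assay for lipophilicity (on this read-out lower numbers stand for lower lipophilicity and higher numbers for higher lipophilicity), the second highest of the three numbers at hand. Compound 2 `CC1(c2ccc(C#N)cc2)SCC(C(C)(C)C)CS1` gives 4.9, and a number 0.52 log units higher from compound 1 to compound 2 (beyond the scatter). Compound 3 `CC(C)(C)C1CS(=O)(=O)C(C)(c2ccc(C#N)cc2)S(=O)(=O)C1` gives 0.351, the lowest of the three; it differs from compound 1 in more than one place, so only the two values can be compared. Compound 4 `C#Cc1ccc(C2SCC(C(C)(C)C)CS2)cc1` is not yet measured; it differs from compound 1 by ethynyl in place of cyano on an aromatic carbon. Within the data shown here, the one measured step, a methyl for a hydrogen on the saturated ring, concerns a different group at a different place and so bears only loosely on this change. The expected step is a number 0.92 log units higher from compound 1 to compound 4 (beyond the scatter), modest and upward. Compound 4 is expected to give 5.3, between 4.8 and 5.8.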

Compound 4, partition coefficient: 4.96
For compound 4 the middle estimate is 0.34 log units above the measured one; the measured number falls inside the stated range.
By their numbers in this assay, from the lowest: compound 3; then compound 1; then compounds 2 and 4 (each within the scatter of the next).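

Ethynyl in place of cyano on an aromatic carbon, para to a large group, gives a number 0.58 log units higher from compound 1 to compound 4 (beyond the scatter) in this assay. Among these compounds, this is the first reading at this position, and it shows that a swap keeping the triple bond and the count of heavy atoms, while removing the nitrogen and its hydrogen-bond acceptor, still moves the number beyond the scatter. No measurement at hand explains this step. The compounds shown leave open how an amine or a carboxylic acid at this position would read. From the compounds shown here alone, whether the same swap gives a similar step on the core of compound 2 or compound 3 also remains open.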